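The source may report more compounds than this note shows. Statements on the series, on what has been measured and on what is new or still open speak of the compounds shown alone.

The series is read in a functional assay on SMMC-7721 cells (Homo sapiens) for inhibition, read by MTT assay; a higher number here means a weaker inhibitor, a lower number a stronger inhibitor. Compound 3 (`CCOC(=O)c1c(NC(=O)CC#N)sc(C(=O)Nc2ccccc2)c1-c1ccccc1`) gives 530 nM and compound 1 (`CCOC(=O)c1c(N)sc(C(=O)Nc2ccc(Cl)cc2)c1-c1ccccc1`) gives 420 nM, two values within the scatter of each other. Compound 2 (`N#Cc1c(N)sc(C(=O)Nc2ccccc2)c1-c1ccccc1`) gives 5090 nM, a number clearly higher than either. Compound 4 (`CCOC(=O)c1c(N)sc(C(=O)Nc2ccccc2)c1-c1ccccc1`) differs from compound 3 by hydrogen in place of (cyanomethyl)carbonyl on a nitrogen on an aromatic ring. Going by the values given here, no measured pair isolates this change. Compound 1 at 420 nM and compound 2 at 5090 nM both carry the free amino group, so their values give only a wide guide. A modest move toward a higher number is expected, an estimated 1.9-fold higher number from compound 3 to compound 4 (0.28 log units; within the scatter). The value of compound 4 is estimated at 1000 nM, with an expected range of 350 nM to 3500 nM.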

Compound 4, half-maximal inhibitory concentration: 8580 nM
The estimate for compound 4 lay 8.6-fold (0.93 log units) below the measured number; the whole stated range lies below it.
By their numbers in this assay, from the lowest: compounds 1 and 3 (each within the scatter of the next); then compounds 2 and 4 (each within the scatter of the next).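

In this assay, the free amino compound is not close to its acylated partner: hydrogen in place of (cyanomethyl)carbonyl on the nitrogen gives a 16-fold higher number from compound 3 to compound 4 (1.21 log units; beyond the scatter). Hydrogen in place of chloro on an aromatic carbon is also a large change, with a 20-fold higher number from compound 1 to compound 4 (1.31 log units; beyond the scatter). Ethoxycarbonyl in place of cyano on an aromatic carbon stays within the scatter, with a 1.7-fold higher number from compound 2 to compound 4 (0.23 log units; within the scatter).

Still open, as far as these compounds go, is whether a plain acetyl or a longer acyl chain on that nitrogen, or fluoro or methyl in place of chloro, would hold the lower numbers. No measurement on hand accounts for these steps.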